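Chloro for fluoro on a pyrrolidinone core: two cases

The source may report more compounds than this note shows. Statements on the series, on what has been measured and on what is new or still open speak of the compounds shown alone.

Measured compounds:
compound 1 `O=C1CC(c2nc(-c3ccc(Cl)cc3)no2)CN1c1ccc(Cl)c(Cl)c1` gives 1100 nM in an in vitro functional assay on HEK293-A cells for positive allosteric modulation of metabotropic glutamate receptor 5 (Homo sapiens), read by FLIPR and calcium flux; on this read-out lower numbers stand for an effect already at smaller amounts and higher numbers for an effect only at larger amounts of compound
compound 3 `O=C1CC(c2nc(-c3ccc(F)cc3)no2)CN1c1ccc(Cl)c(Cl)c1` gives 2300 nM in this assay
compound 2 `Cc1cccc(-c2noc(C3CC(=O)N(c4ccc(F)cc4)C3)n2)n1` gives > 10000 nM in this assay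

The value for compound 2 is a limit of this assay, not a number (the limit of > 10000 nM in this assay, at which 1 of the 3 values shown sits). Compound 1 and compound 3 share one core; compound 2 carries another, and the difference between the two cores is not broken down here.

Between compound 3 and compound 1 the change is chloro in place of fluoro on an aromatic carbon, and it brought a 2.1-fold lower number from compound 3 to compound 1 (0.32 log units; beyond the scatter).

Compound 4 `Cc1cccc(-c2noc(C3CC(=O)N(c4ccc(Cl)cc4)C3)n2)n1` has not been measured. It differs from compound 2 by chloro in place of fluoro on an aromatic carbon, the same kind of change as from compound 3 to compound 1, made on a different core. Resting on the step from compound 3 to compound 1, compound 4 is expected to show a step of an at least 1.2-fold lower number from compound 2 to compound 4 (0.09 log units; that floor lies within the scatter) in this assay, though since compound 2 sits at a limit, a limit again is quite possible. Compound 4 is estimated at 8000 nM, with a likely range from 3000 nM to 30000 nM.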

Compound 4, half-maximal effective concentration in the metabotropic glutamate receptor 5 assay: > 10000 nM
Compound 4: only a limit was reported; the forecaster's own chance of this, stated with the estimate: 55%; middle value at least 1.2-fold (0.09 log units) away from the limit.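

In the metabotropic glutamate receptor 5 assay compound 2 gives > 10000 nM, which is a limit and not a number. In the metabotropic glutamate receptor 5 assay compound 4 gives > 10000 nM, which is also a limit and not a number. Compound 2 and compound 4 both sit at a limit rather than at a number, so no step between them can be read in the metabotropic glutamate receptor 5 assay: the limit of > 10000 nM in the metabotropic glutamate receptor 5 assay, at which 2 of the 4 values shown sit.

As far as these compounds go, whether chloro in place of fluoro changes the number at all on the core of compound 2, as it did on the core of compound 1, stays open.

In a physicochemical assay for solubility, read by HPLC (a higher number here means a more soluble compound, a lower number a less soluble compound), compound 2 gives 26000 nM and compound 4 gives 26000 nM. In the physicochemical assay chloro in place of fluoro brought no change at the digits printed from compound 2 to compound 4 (within the scatter).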